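A few compounds are considered here, and "the series" means these few. Any claim that something is new, unique, unknown or untested is made for them only; others in the source may bear on it.

Compound 1 `Nc1ncnn2c([C@@H]3O[C@H](CO)[C@@H](O)[C@H]3O)cc(C#CC3CC3)c12` gives 20 nM in a functional assay on CAPAN-1 cells (Homo sapiens) for antiproliferative activity, with a stated time of 72 h; on this read-out lower numbers stand for stronger inhibition and higher numbers for weaker inhibition.
Compound 2 `Nc1ncnn2c([C@@H]3O[C@H](CO)[C@@H](O)[C@H]3O)cc(-c3ccc(Cl)cc3)c12` gives 56700 nM.
Compound 3 `Nc1ncnn2c([C@@H]3O[C@H](CO)[C@@H](O)[C@H]3O)cc(-c3ccoc3)c12` gives 900 nM.

Compound 1 stands lowest of the three numbers. Replacing its 2-cyclopropylethynyl group with an aromatic ring raised the number in both measured steps: a 2800-fold higher number from compound 1 to compound 2 (3.45 log units; beyond the scatter) and a 45-fold higher number from compound 1 to compound 3 (1.65 log units; beyond the scatter). Compound 4 `Nc1ncnn2c([C@@H]3O[C@H](CO)[C@@H](O)[C@H]3O)cc(/C=C/c3ccccc3)c12` carries the change (2-phenylethenyl in place of 2-cyclopropylethynyl on an aromatic carbon). Both steps away from compound 1 bear on it and both were large and upward, though in compound 4 the aromatic ring sits on a double bond outside aromatic rings rather than being attached directly. A rise beyond the scatter is therefore expected for compound 4, a 25-fold higher number from compound 1 to compound 4 (1.40 log units; beyond the scatter), smaller than the step to compound 2. Compound 4 is estimated at 500 nM, with a range from 50 nM to 5000 nM.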

Compound 4, half-maximal inhibitory concentration: 2600 nM
The estimate for compound 4 lay 5.2-fold (0.72 log units) below the measured number; measured number inside the range.
By their numbers in this assay, from the lowest: compound 1; then compound 3; then compound 4; then compound 2.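

Putting the phenyl ring on a double bond did not bring the number back to that of the 2-cyclopropylethynyl group, with a 130-fold higher number from compound 1 to compound 4 (2.11 log units; beyond the scatter), yet this group still gave a far lower number than 4-chlorophenyl, with a 22-fold lower number from compound 2 to compound 4 (1.34 log units; beyond the scatter). Against furan-3-yl the change was only modest, with a 2.9-fold higher number from compound 3 to compound 4 (0.46 log units; beyond the scatter), so a ring-bearing group at this position can give very different numbers depending on how it is built. Nothing available here accounts for these differences. Going by these compounds, whether the triple bond or the cyclopropyl ring matters more for the low number of compound 1 stays open, as does how a 2-phenylethynyl group or a simple amine would stand at this position.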